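A few compounds are considered here, and "the series" means these few. Any claim that something is new, unique, unknown or untested is made for them only; others in the source may bear on it.

Measured compounds:
compound 1 `Cc1ncnc2c1c(-c1cccs1)cn2[C@@H]1O[C@H](CO)[C@@H](O)[C@H]1O` — in a functional assay on K562 cells (Homo sapiens), read by MTT assay, with a stated time of 72 h (a higher number here means a weaker inhibitor, a lower number a stronger inhibitor), compound 1 gives > 20000 nM
compound 2 `Cc1ncnc2c1c(-c1ccsc1)cn2[C@@H]1O[C@H](CO)[C@@H](O)[C@H]1O` — in this assay compound 2 gives 5550 nM
compound 3 `C#Cc1cn([C@@H]2O[C@H](CO)[C@@H](O)[C@H]2O)c2ncnc(C)c12` — in this assay compound 3 gives 110 nM

The value of compound 1 is a limit of the assay, not a number (the limit of > 20000 nM in this assay, at which 1 of the 3 values shown sits); compound 1 therefore stands at the weak end of what has been measured. Compound 4 `CN(C)c1ncnc2c1c(-c1cccs1)cn2[C@@H]1O[C@H](CO)[C@@H](O)[C@H]1O` differs from compound 1 by dimethylamino in place of methyl on an aromatic carbon. The measured steps all change a group on a different aromatic carbon of the shared core: an at least 3.6-fold lower number from compound 1 to compound 2 (0.55 log units; beyond the scatter), an at least 180-fold lower number from compound 1 to compound 3 (2.25 log units; beyond the scatter) and a 50-fold lower number from compound 2 to compound 3 (1.70 log units; beyond the scatter). None of them touches the carbon changed in compound 4, so they offer no direct guide. The expectation is that compound 4 stays close to compound 1, with no step beyond the scatter: a step that the limit leaves unreadable from compound 1 to compound 4. Compound 4 is estimated at 30000 nM, in a range from 8000 nM to 100000 nM, most likely reported again only as a limit.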

Compound 4, half-maximal inhibitory concentration: > 20000 nM
Compound 4: a limit, no number; the forecaster's own chance of this, stated with the estimate: 75%; the middle value is on the limit's open side.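

Within the data shown here, compound 1 and compound 4 both give only a limit in this assay and no number, so no step between them can be read: the limit of > 20000 nM in this assay, at which 2 of the 4 values shown sit. The compounds shown leave open whether dimethylamino in place of methyl changes the result at all.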